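Benzyl for Acetyl: The Step to Compound 4

The source may report more compounds than this note shows. Statements on the series, on what has been measured and on what is new or still open speak of the compounds shown alone.

In a functional assay on KB 3-1 cells (Homo sapiens) for inhibition, with a stated time of 72 h (on this read-out higher numbers stand for weaker inhibition and lower numbers for stronger inhibition), compound 2 (`CC(=O)Oc1cc2oc(-c3ccccc3)cc(=O)c2c(OC(C)=O)c1OC(C)=O`) gives 57200 nM and compound 1 (`CC(=O)Oc1c(O)cc2oc(-c3ccccc3)cc(=O)c2c1O`) gives 61600 nM so these two lie within the scatter of each other. Compound 3 (`CC(=O)Oc1cc2oc(-c3ccccc3)cc(=O)c2c(OCc2ccccc2)c1OC(C)=O`) gives 12200 nM and is the furthest of the three from compound 2. Compound 4 (`CC(=O)Oc1c(OCc2ccccc2)cc2oc(-c3ccccc3)cc(=O)c2c1OC(C)=O`) has not yet been measured in this assay and differs from compound 2 as follows: benzyl in place of acetyl on an oxygen on an aromatic ring In words, this is benzyl in place of acetyl on an oxygen on an aromatic ring.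

Among the compounds with values here, only one measured step bears on this change. Compound 3 carries the same kind of swap on another oxygen of the shared core, and that swap gave a 4.7-fold lower number from compound 2 to compound 3 (0.67 log units; beyond the scatter) as a modest step beyond the scatter. This single example cannot show whether the swap would act alike on a different oxygen, so some of its size may be lost, and a step beyond the scatter in the same direction is a reasonable but uncertain expectation. The expected step is a 3.2-fold lower number from compound 2 to compound 4 (0.50 log units; beyond the scatter) in this estimate. For compound 4 the estimated value is 18000 nM with an expected range from 7000 nM to 45000 nM on this read-out.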

Compound 4, half-maximal inhibitory concentration: 13700 nM
For compound 4 the middle estimate is 1.3-fold (0.12 log units) above the measured one; low and high end bracket the measured number.
By their numbers in this assay, from the lowest: compounds 3 and 4 (each within the scatter of the next); then compounds 2 and 1 (each within the scatter of the next).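

In this assay, within the data shown here, benzyl in place of acetyl on this second oxygen gives a 4.2-fold lower number from compound 2 to compound 4 (0.62 log units; beyond the scatter), so the drop in the number is no longer tied to the single oxygen changed in compound 3. That earlier swap gave a 4.7-fold lower number from compound 2 to compound 3 (0.67 log units; beyond the scatter), which points the same way and is also a modest step beyond the scatter, and compound 3 and compound 4 lie within the scatter of each other. Across these two oxygens of the shared core, the change from acetoxy to benzyloxy therefore reads alike, although two examples set no rule for any other oxygen, and no measurement given here explains the effect.

The compounds shown do not tell whether the six-membered aromatic ring of the benzyl group matters or whether a plain longer chain, such as butyl or hexyl, on the same oxygen would give a similar step. They also leave open what benzyl on both of these oxygens together would do, and how a chain ending in an amine or a carboxylic acid would read out here.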